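Pyrazin-2-yl amine replacing 4-methoxypyridin-2-yl amine

The source may report more compounds than this note shows. Statements on the series, on what has been measured and on what is new or still open speak of the compounds shown alone.

Three compounds have numbers in an ADME assay on microsomes from liver (Homo sapiens) for metabolic stability, read by LC-MS, with a stated time of 30 min, tested at 0.1 uM; a higher number here means that more of the compound is left, a lower number that less of the compound is left. Compound 1 `FC(F)(F)Oc1ccc(-c2nc3cnc(Nc4ccccn4)cc3[nH]2)cc1` gives 60%; compound 2 `COc1cccc(Nc2cc3[nH]c(-c4cccc(C(F)(F)F)c4)nc3cn2)n1` gives 45%; compound 3 `COc1ccnc(Nc2cc3[nH]c(-c4cccc(C(F)(F)F)c4)nc3cn2)c1` gives 80%. Compound 3 stands highest of the three, beyond the scatter from both others. Among the measured compounds shown here, the only single-point step among them, a number 35 percentage points higher from compound 2 to compound 3 (beyond the scatter), is large. Compound 4 `FC(F)(F)c1cccc(-c2nc3cnc(Nc4cnccn4)cc3[nH]2)c1` differs from compound 3 by pyrazin-2-yl in place of 4-methoxypyridin-2-yl on a nitrogen on an aromatic ring. For the measured compounds named here, no measured step removes a methoxy group or trades a ring with 1 hetero atom for one with 2 hetero atoms, so the known step does not bear directly on this change; the measured compounds merely set the spread. Compound 4 is expected at an estimated 65%, range 40% to 88%. That estimate means an expected step of a number 15 percentage points lower from compound 3 to compound 4 (beyond the scatter), downward and modest.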

Compound 4, percent of the compound remaining: 43%
Compound 4: the middle estimate sits 22 percentage points above what was measured; measured number inside the range.
By their numbers in this assay, from the lowest: compounds 4 and 2 (each within the scatter of the next); then compound 1; then compound 3.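

Replacing the 4-methoxypyridin-2-yl group with pyrazin-2-yl on the nitrogen gives a number 37 percentage points lower from compound 3 to compound 4 (beyond the scatter) in this assay, so the number at this position does not hold across these rings. Pyrazin-2-yl in place of 6-methoxypyridin-2-yl gives a number 2 percentage points lower from compound 2 to compound 4 (within the scatter), which leaves the 4-methoxypyridin-2-yl group alone at the high end among these three groups. Nothing measured here gives a reason for either step.

Still open, on these data alone, is whether the methoxy group itself carries the higher number, or whether an ethoxy group or an amine in its place would do the same.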